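Chloro on the phenyl of compound 3: compound 4

The source may report more compounds than this note shows. Statements on the series, on what has been measured and on what is new or still open speak of the compounds shown alone.

Of the compounds shown here, three on the shared core have numbers so far. Compound 1 `C=CCc1ccc(O)c(-c2cc(CC=C)cc(CN(C)c3ccccc3)c2O)c1` gives 15.5% in an assay on isolated protein for inhibition of Maltase-glucoamylase (Homo sapiens), with stated times of 15 min and 10 min, tested at 64 uM; a lower number here means less inhibition, a higher number more inhibition at the concentration tested (going by the name of the read-out). Compound 2 `C=CCc1cc(-c2ccc(O)c(CC=C)c2)c(O)c(C(c2ccccc2)N2CCCCC2)c1` gives 13.6% in this assay, and compound 3 `C=CCc1cc(-c2ccc(O)c(CC=C)c2)c(O)c(C(c2ccccc2)N2CCC(C)CC2)c1` gives 25.8% in this assay. Among the compounds with values here, the one single-place step measured, a number 12.2 percentage points higher from compound 2 to compound 3 (beyond the scatter), shows a methyl in place of hydrogen on a saturated ring carbon. Compound 3 therefore stands highest of the three numbers, beyond the scatter from both compound 1 and compound 2.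

Compound 4 `C=CCc1cc(-c2ccc(O)c(CC=C)c2)c(O)c(C(c2ccc(Cl)cc2)N2CCC(C)CC2)c1` differs from compound 3 by chloro in place of hydrogen on an aromatic carbon. Within the data shown here, the change sits on the phenyl, para to a large group, and no measured step touches that ring; the only step known, a number 12.2 percentage points higher from compound 2 to compound 3 (beyond the scatter), concerns the saturated ring instead and says nothing about a chloro on an aromatic carbon. Among the measured compounds shown here, with no comparable step, no move beyond the scatter is expected in this assay, and the estimated step is a number 2.2 percentage points higher from compound 3 to compound 4 (within the scatter). Compound 4 is estimated at 28% in this assay, with a range from 14% to 44%.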

Compound 4, a percentage reported as inhibition, at one concentration (the size of the read-out at that concentration, not a potency): 8.6%
Beside the measured number, compound 4's estimate is 19.4 percentage points above it; measured number outside the range, below it.
By their numbers in this assay, from the lowest: compounds 4, 2 and 1 (each within the scatter of the next); then compound 3.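

In this assay the phenyl turns out to be a position that responds, with phenyl to 4-chlorophenyl giving a number 17.2 percentage points lower from compound 3 to compound 4 (beyond the scatter) on a compound that keeps its methyl on the saturated ring. The earlier step, a number 12.2 percentage points higher from compound 2 to compound 3 (beyond the scatter) at the saturated ring, went up, whereas this one goes down, so both places move the number, in opposite directions. Nothing shown explains why the chloro lowers the number.

Only hydrogen and chloro are shown at this place, so it stays open whether the drop belongs to chloro itself or to any group there, which a fluoro, a methoxy or an amine on the phenyl would separate. Also open, going by these compounds, is whether chloro on the phenyl of compound 2, without the methyl, gives a step of the same direction.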